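Chloro for sulfamoyl on the anilide of a triazole series

The source may hold more compounds than are shown below. What is called first, only, known or untested is meant among the compounds shown, and "the series" means these compounds.

Going by the values given here, compound 3 `NS(=O)(=O)c1ccc(NC(=O)CSc2nnc(COc3ccc4ccccc4c3)n2Cc2ccccc2)cc1` carries a 4-sulfamoylphenyl amide on the shared core and, in a toxicity assay on MT4 cells (Homo sapiens) for cytotoxicity, read by MTT assay, with a stated time of 5 days (on this read-out higher numbers stand for lower toxicity in this test and lower numbers for higher toxicity in this test), compound 3 gives 94.5 ug/mL, the highest of the three numbers so far. The nearest is compound 1 `Cc1ccc(C(C)C)c(OCc2nnc(SCC(=O)Nc3ccc(Cl)cc3)n2Cc2ccccc2)c1`, which in this assay gives 65.9 ug/mL, a gap that stays within the scatter, so the two are not separated. Among the compounds with values here, the furthest is compound 2 `CC(=O)Nc1ccc(OCc2nnc(SCC(=O)Nc3ccc(Cl)cc3)n2Cc2ccccc2)cc1`, which gives 14 ug/mL; the only single-point step so far, a 4.7-fold lower number from compound 1 to compound 2 (0.67 log units; beyond the scatter), sits on the ether side of the core, not on the anilide.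

Compound 4 `O=C(CSc1nnc(COc2ccc3ccccc3c2)n1Cc1ccccc1)Nc1ccc(Cl)cc1` differs from compound 3 by chloro in place of sulfamoyl on an aromatic carbon. Within the data shown here, no measured pair bears on this change: the one step recorded concerns the aryl ether, and the amide ring of compounds 1 and 2 is already the 4-chlorophenyl of compound 4, so the chloro anilide is represented only alongside other changes. With nothing to push it, the expectation is a step no larger than the scatter, a 1.6-fold lower number from compound 3 to compound 4 (0.20 log units; within the scatter), though the lower numbers of compounds 1 and 2 leave room downward. Compound 4 is therefore expected to give about 60 ug/mL, with a range of 20 ug/mL to 120 ug/mL.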

Compound 4, half-maximal cytotoxic concentration: >= 4.93 ug/mL
Compound 4 ended at the assay's limit; the forecaster's own chance of this, stated with the estimate: 10%; the middle value is on the limit's open side.
By their numbers in this assay, from the lowest: compound 2; then compounds 1 and 3 (each within the scatter of the next).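

In this assay compound 4 gives >= 4.93 ug/mL, which is a limit and not a number; the steps from compounds 1, 2 and 3 to compound 4 cannot be read. Still open, as far as these compounds go, is what chloro in place of sulfamoyl does to the number on the shared core, and whether compound 4 lies with compound 2 or with compounds 1 and 3.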